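Bromo replaces methylpiperazinyl on a quinazolinone scaffold

The source may hold more compounds than are shown below. What is called first, only, known or untested is meant among the compounds shown, and "the series" means these compounds.

Measured compounds:
compound 2 `CN1CCN(c2ccc(-c3cc(-c4ccc(C5NC(=O)c6ccccc6N5)cc4)nc(N)n3)cc2)CC1`, in an ADME assay on Vero cells (Chlorocebus sabaeus) for cytotoxicity, read by MTT assay, with a stated time of 72 h (on this read-out lower numbers stand for higher toxicity in this test and higher numbers for lower toxicity in this test), compound 2 gives 8320 nM
compound 3 `CCCNc1nc(NCCC)nc(Nc2ccc(C3(C)NC(=O)c4ccccc4N3)cc2)n1`, in this assay compound 3 gives > 400000 nM
compound 1 `CCCCNC(c1ccc(C2NC(=O)c3ccccc3N2)cc1)c1nnnn1C(C)(C)C`, in this assay compound 1 gives "not determined" (no result reported)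

Going by the values given here, compound 2 carries the only plain number in this assay; the other two entries are a limit and a missing result. For compound 3 the value > 400000 nM is a limit of the assay and not a number, as the evidence notes: the limit of > 400000 nM in this assay, at which 1 of the 3 values shown sits. Compound 1 has no result in this assay, so nothing can be said of its toxicity here.

Compound 4 `Nc1nc(-c2ccc(Br)cc2)cc(-c2ccc(C3NC(=O)c4ccccc4N3)cc2)n1` is not yet measured. It differs from compound 2 in one place: bromo in place of 4-methylpiperazin-1-yl on an aromatic carbon. Among the compounds with values here, no step between two measured compounds is recorded, so there is no measured reference for the size of this change. The author expects a step in this assay from compound 2 to compound 4 of modest size toward lower toxicity, not far beyond the scatter, a 1.8-fold higher number from compound 2 to compound 4 (0.26 log units; within the scatter). The author estimates for compound 4 in this assay a value of 15000 nM, within the range 3000 nM to 80000 nM.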

Compound 4, half-maximal cytotoxic concentration: > 400000 nM
Compound 4 ended at the assay's limit (the forecaster's own chance of this, stated with the estimate: 10%); at least 26-fold (1.42 log units) between middle value and limit.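

In this assay, going by these compounds alone, this position proves far more sensitive than the earlier compounds could show, since bromo in place of 4-methylpiperazin-1-yl on this aromatic carbon gives an at least 48-fold higher number from compound 2 to compound 4 (1.68 log units; beyond the scatter). This single change on the ring of carbon only is enough to move the read-out from a plain number to the top of the measurable range, toward lower toxicity in this test. Compound 4 gives > 400000 nM, which is a limit of the assay and not a number, so the step has a lower bound but no known full size: the limit of > 400000 nM in this assay, at which 2 of the 4 values shown sit.

From the compounds shown here alone, whether another amine at this position, such as morpholin-4-yl or dimethylamino, would stay near compound 2 remains open. So does whether a smaller halogen such as fluoro or chloro would also reach the limit.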